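Ester Group Changes and Half-Life in Intestinal Microsomes

This account rests on a few compounds, and the source may have more. Where it says the series, first, only, none or still open, it means among the compounds named here.

Compound 1 `CCOc1cc(NC(=O)C2(NC(=O)c3ccc4c(C5CCCC5)c(-c5ncc(Cl)cn5)n(C)c4c3)CCC2)ccc1/C=C/C(=O)OCOP(=O)(O)O`: 0.0833 h
Compound 2 `CCOc1cc(NC(=O)C2(NC(=O)c3ccc4c(C5CCCC5)c(-c5ncc(Cl)cn5)n(C)c4c3)CCC2)ccc1/C=C/C(=O)OCc1ccccc1`: > 5 h
Compound 3 `CCOc1cc(NC(=O)C2(NC(=O)c3ccc4c(C5CCCC5)c(-c5ncc(Cl)cn5)n(C)c4c3)CCC2)ccc1/C=C/C(=O)OCC(=O)N1CCOCC1`: not yet measured

Of the compounds shown here, two have been measured in an ADME assay (intestine, Rattus norvegicus) for pharmacokinetics, using microsomes; on this read-out higher numbers stand for a longer-lived compound and lower numbers for a shorter-lived compound. Compound 1 gives 0.0833 h in this assay. For compound 2 the result > 5 h is a limit of the assay and not a number. Compound 2 therefore sits at the limit of > 5 h in this assay, at which 1 of the 2 values shown sits, so its true value is open upward. Within the data shown here, the one measured step at this position, an at least 60-fold higher number from compound 1 to compound 2 (1.77 log units; beyond the scatter), is known only as a lower bound on its size, yet it shows that a change at the saturated chain carbon bound to an oxygen next to a carbonyl group can move the read-out far. Compound 3 differs from compound 2 by (morpholin-4-yl)carbonyl in place of phenyl on a saturated chain carbon bound to an oxygen next to a carbonyl group. Because compound 2 carries only a limit, the size of the coming step is uncertain; a shorter half-life than that limit is expected, though not down to where compound 1 stands. The estimate for compound 3 is 1 h, in the range 0.15 h to 5 h. This expected value corresponds to an estimated step of an at least 5.0-fold lower number from compound 2 to compound 3 (0.69 log units; beyond the scatter).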

Compound 3, half-life: 1.27 h
Estimate against measurement, compound 3: 1.3-fold (0.10 log units) below; measured number inside the range.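

In this assay, among these compounds, the saturated chain carbon bound to an oxygen next to a carbonyl group now proves able to give an intermediate read-out, not only the two extremes seen so far, and a 15-fold higher number from compound 1 to compound 3 (1.18 log units; beyond the scatter) is the first step at this position with a number at both ends. Placing (morpholin-4-yl)carbonyl where phenyl stood gives an at least 3.9-fold lower number from compound 2 to compound 3 (0.59 log units; beyond the scatter), so the two groups are separated beyond the scatter. That step is known only as a lower bound because the result for compound 2 is a limit of the assay and not a number: the limit of > 5 h in this assay, at which 1 of the 3 values shown sits.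

The compounds shown leave open how far compound 2 lies beyond its limit, and so the full size of this change. They also leave open where a piperidin-1-ylcarbonyl group or a plain ethyl group would fall at this position.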